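A few compounds are considered here, and "the series" means these few. Any claim that something is new, unique, unknown or untested is made for them only; others in the source may bear on it.

Compound 1 `COc1cc2c(Nc3ccc(C#N)cc3)ncnc2cc1OCCCN(C)C` carries a dimethylamino group on the chain; in a functional assay on DU-145 cells (Homo sapiens) for antiproliferative activity, read by MTT assay, with a stated time of 72 h (on this read-out higher numbers stand for weaker inhibition and lower numbers for stronger inhibition), compound 1 gives 35300 nM, the highest of the two numbers recorded here. Compound 2 `COc1cc2c(Nc3ccc(C#N)cc3)ncnc2cc1OCCCN(C)Cc1ccccc1` reaches only a limit, > 100000 nM. Compound 3 `COc1cc2c(Nc3ccc(C#N)cc3)ncnc2cc1OCCCN1CCC(c2ccccc2)CC1` gives 6790 nM. The open-chain benzyl change produced an at least 2.8-fold higher number from compound 1 to compound 2 (0.45 log units; beyond the scatter), whereas the cyclic amine produced a 5.2-fold lower number from compound 1 to compound 3 (0.72 log units; beyond the scatter). Compound 4 `COc1cc2c(Nc3ccc(C#N)cc3)ncnc2cc1OCCCN1CCN(c2ccncc2)CC1` differs from compound 1 by 4-(pyridin-4-yl)piperazin-1-yl in place of dimethylamino on a saturated chain carbon, three bonds along the chain from an oxygen on an aromatic ring. Because the cyclic replacement gave a 5.2-fold lower number from compound 1 to compound 3 (0.72 log units; beyond the scatter) while the open-chain one gave an at least 2.8-fold higher number from compound 1 to compound 2 (0.45 log units; beyond the scatter), the ring amine of compound 4 bears most on this step. Compound 4 is therefore expected to show a 3.2-fold lower number from compound 1 to compound 4 (0.51 log units; beyond the scatter), a modest drop. Compound 4 is estimated at 11000 nM in this assay, within 3500 nM to 40000 nM.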

Compound 4, half-maximal inhibitory concentration: 22900 nM
Estimate against measurement, compound 4: 2.1-fold (0.32 log units) below; the range from low to high includes it.
By their numbers in this assay, from the lowest: compound 3; then compounds 4 and 1 (each within the scatter of the next). At a limit, above all of these: compound 2.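

With 4-(pyridin-4-yl)piperazin-1-yl on this saturated chain carbon, the data show a 1.5-fold lower number from compound 1 to compound 4 (0.19 log units; within the scatter) and so a ring amine in place of dimethylamino does not by itself set a compound apart. What the ring carries counts, with a 3.4-fold higher number from compound 3 to compound 4 (0.53 log units; beyond the scatter) on exchanging 4-phenylpiperidin-1-yl for this group. The remaining step, an at least 4.3-fold lower number from compound 2 to compound 4 (0.64 log units; beyond the scatter) here, rests on a limit of the assay: the limit of > 100000 nM in this assay, at which 1 of the 4 values shown sits.

The compounds shown leave open how a morpholine or an unsubstituted piperidine would read at this place. They also leave open what a longer chain would do for 4-phenylpiperidin-1-yl.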